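Carbamoyl in place of phenylthiocarbamoyl on the amine nitrogen

This account rests on a few compounds, and the source may have more. Where it says the series, first, only, none or still open, it means among the compounds named here.

Compound 3 `N#CC1=C(NC(=S)Nc2ccccc2)N(c2ccc(S(N)(=O)=O)cc2)C2=C(C(=O)CCC2)C1c1ccc(Cl)cc1Cl` gives 40% in a functional assay on Ehrlich cells (Mus musculus) for cytotoxicity, read by trypan blue exclusion, with a stated time of 2 h, tested at 10 ug/mL (on this read-out higher numbers stand for a stronger effect at the one concentration tested and lower numbers for a weaker effect), level with compound 1 `N#CC1=C(N)N(c2ccc(S(N)(=O)=O)cc2)C2=C(C(=O)CCC2)C1c1ccc(Cl)cc1Cl`, which gives 40%; together they are the highest of the three numbers, while compound 2 `CCCCNC(=S)NC1=C(C#N)C(c2ccc(Cl)cc2Cl)C2=C(CCCC2=O)N1c1ccc(S(N)(=O)=O)cc1` gives 30%. None of these gaps leaves the scatter: no change at the digits printed from compound 1 to compound 3 (within the scatter), a number 10 percentage points lower from compound 1 to compound 2 (within the scatter) and a number 10 percentage points higher from compound 2 to compound 3 (within the scatter).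

Compound 4 `N#CC1=C(NC(N)=O)N(c2ccc(S(N)(=O)=O)cc2)C2=C(C(=O)CCC2)C1c1ccc(Cl)cc1Cl` differs from compound 3 by a group of 3 heavy atoms (1 carbon, 1 nitrogen, 1 oxygen; no ring) in place of a group of 9 heavy atoms (7 carbon, 1 nitrogen, 1 sulfur; one six-membered aromatic ring of carbon only), on an amine nitrogen. Going by the values given here, the steps that bear on this place are those above: the hydrogen of compound 1 could be exchanged for the larger thiourea groups of compound 2 and compound 3 with no shift beyond the scatter, and exchanging butyl for phenyl on the same nitrogen likewise stayed within it. The smaller carbamoyl group of compound 4 is a further change at the same nitrogen, so no step beyond the scatter is expected: no change at the digits printed from compound 3 to compound 4 (within the scatter). The estimate for compound 4 is 40%, within a range from 25% to 55%.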

Compound 4, a percentage reported as activity, at one concentration (the size of the read-out at that concentration, not a potency): 20%
Estimate against measurement, compound 4: 20 percentage points above, and the stated range ends above it.
By their numbers in this assay, from the lowest: compounds 4, 2, 1 and 3 (each within the scatter of the next, the first and the last beyond it).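

Going by these compounds alone, at the amine nitrogen, compound 4 gives the first steps beyond the scatter in this assay: carbamoyl in place of hydrogen gives a number 20 percentage points lower from compound 1 to compound 4 (beyond the scatter), and carbamoyl in place of the larger phenylthiocarbamoyl group gives a number 20 percentage points lower from compound 3 to compound 4 (beyond the scatter). This nitrogen therefore does not tolerate every group equally, and the smallest group placed on it separates from the free amine, while the phenylthiocarbamoyl of compound 3 does not. Against the butyl thiourea, the carbamoyl group does not separate: a number 10 percentage points lower from compound 2 to compound 4 (within the scatter).

Nothing shown explains this drop. Compound 4 exchanges sulfur for oxygen and drops the phenyl at once, so the two changes cannot be told apart, and a phenylcarbamoyl or an unsubstituted thiocarbamoyl group would be needed to separate them.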